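Swapping Fluoro for Hydrogen on Compound 3

This account rests on a few compounds, and the source may have more. Where it says the series, first, only, none or still open, it means among the compounds named here.

In a functional assay on Jurkat cells (Homo sapiens) for cytotoxicity, read by luminescence and CellTiter-Glo, with a stated time of 3 days (a lower number here means a stronger inhibitor, a higher number a weaker inhibitor), compound 1 (`O=C(Nc1ccc(C(F)(F)F)cc1)c1cc(Cl)ccc1O`) gives 710 nM and compound 2 (`O=C(Nc1ccc(C(F)(F)F)cc1)c1cc(F)ccc1O`) gives 580 nM while compound 3 (`O=C(Nc1ccc(C(F)(F)F)cc1)c1cc(Br)c(F)cc1O`) gives 880 nM and so lies within the scatter of both. Compound 4 (`O=C(Nc1ccc(C(F)(F)F)cc1)c1cc(Br)ccc1O`) has not yet been measured. It carries hydrogen in place of fluoro on an aromatic carbon. Going by the values given here, no measured step replaces a halogen with hydrogen. The closest one swaps one halogen for another: a 1.2-fold lower number from compound 1 to compound 2 (0.09 log units; within the scatter) with fluoro in place of chloro stays within the scatter. No step beyond the scatter is therefore expected in this assay and the estimated step is a 1.3-fold lower number from compound 3 to compound 4 (0.10 log units; within the scatter) in size. Compound 4 is estimated at 700 nM (expected range 350 nM to 1500 nM).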

Compound 4, half-maximal inhibitory concentration: 620 nM
Compound 4: middle estimate off by 1.1-fold (0.05 log units), on the high side; the measured number falls inside the stated range.
By their numbers in this assay, from the lowest: compounds 2, 4, 1 and 3 (each within the scatter of the next).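

In this assay the fluoro group ortho to the bromo group can give way to hydrogen with no change beyond the scatter (a 1.4-fold lower number from compound 3 to compound 4 (0.15 log units; within the scatter)), so a halogen at this position is not needed to hold the number. With hydrogen there, bromo also reads alike with fluoro (a 1.1-fold higher number from compound 2 to compound 4 (0.03 log units; within the scatter)) and with chloro (a 1.1-fold lower number from compound 1 to compound 4 (0.06 log units; within the scatter)) on the aromatic carbon that varies among compounds 1, 2 and 4. No measured evidence explains these results.

Still open, from the compounds shown here alone, is whether an amine or a methoxy group in place of that fluoro would also leave the number within the scatter.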